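This account rests on a few compounds, and the source may have more. Where it says the series, first, only, none or still open, it means among the compounds named here.

Measured compounds:
compound 1 `C=CC(=O)N1C(=O)CC(c2ccc(-c3ccccc3)cc2)Sc2ccccc21`, 118000 nM
compound 2 `C=CC(=O)N1C(=O)CC(c2ccccc2C(F)(F)F)Sc2ccccc21`, 96400 nM

In a functional assay on HL-60 cells (Homo sapiens) for cytotoxicity, read by CCK-8 assay, with a stated time of 24 h (a lower number here means a stronger inhibitor, a higher number a weaker inhibitor), compound 1 gives the highest of the two numbers; its nearest neighbour is compound 2, and the gap between them lies within the scatter, so the two read as alike. Compound 3 `C=CC(=O)N1C(=O)CC(c2ccc(Br)cc2)Sc2ccccc21` differs from compound 1 by a single change: bromo in place of phenyl on an aromatic carbon. Within the data shown here, no measured step of this kind is at hand, so the expectation rests only on the two values shown, both weak. Compound 3 is expected to stay in the same weak range, with the step of a 1.2-fold lower number from compound 1 to compound 3 (0.07 log units; within the scatter) expected to lie within the scatter. The estimate for compound 3 in this assay is 100000 nM, expected to fall between 40000 nM and 250000 nM.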

Compound 3, half-maximal inhibitory concentration: 126000 nM
Compound 3: the middle estimate sits 1.3-fold (0.10 log units) below what was measured; the range from low to high includes it.
By their numbers in this assay, from the lowest: compounds 2, 1 and 3 (each within the scatter of the next).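

In this assay, the step is a 1.1-fold higher number from compound 1 to compound 3 (0.03 log units; within the scatter), so compound 1 and compound 3 read as alike. On an aromatic carbon para to a large group, a single bromine atom and a phenyl ring of six carbons therefore give no separable difference in this pair, and both remain weak. No measured evidence bears on why these two read alike.

Going by these compounds, whether an amine or a carboxylic acid on this carbon would read apart from these values stays open. So does whether any substituent here can move the value beyond the scatter.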